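Compound 3: one group exchanged on the shared core

A few compounds are considered here, and "the series" means these few. Any claim that something is new, unique, unknown or untested is made for them only; others in the source may bear on it.

In an ADME assay on MT4 cells (Homo sapiens) for cytotoxicity, read by MTT assay, with a stated time of 5 days (a higher number here means that more compound is tolerated, a lower number that less compound is tolerated), compound 1 (`COc1cc2nc(Nc3ccc(C#N)cc3)nc(Nc3c(F)cc(/C=C/C#N)cc3F)c2cc1OC`) gives 6400 nM and compound 2 (`COc1cc2nc(Nc3ccc(C#N)cc3)nc(Nc3c(C)cc(/C=C/C#N)cc3C)c2cc1OC`) gives 10200 nM. These two values lie within the scatter of each other, so compound 2 stands level with compound 1 on the numbers available.

Compound 3 (`COc1cc2nc(Nc3ccc(C#N)cc3)nc(Nc3c(Cl)cc(/C=C/C#N)cc3Cl)c2cc1OC`) keeps the shared core and differs from compound 2 in one group, on a nitrogen on an aromatic ring: a group of 12 heavy atoms (9 carbon, 1 nitrogen, 2 chlorine; one six-membered aromatic ring of carbon only) in place of a group of 12 heavy atoms (11 carbon, 1 nitrogen; one six-membered aromatic ring of carbon only), on a nitrogen on an aromatic ring. The 4-(2-cyanoethenyl)-2,6-dimethylphenyl group leaves, and a group with 2 chlorine enters.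

Within the data shown here, only one measured step bears on this exchange, at the same place: a 1.6-fold higher number from compound 1 to compound 2 (0.20 log units; within the scatter). That step lies within the scatter, and it swaps a group with 2 fluorine for the 4-(2-cyanoethenyl)-2,6-dimethylphenyl group. Among the measured compounds shown here, no compound with 2 chlorine has a measured value yet, and a single step gives no direction. No change beyond the scatter is therefore expected in this assay. The estimated step is a 1.3-fold lower number from compound 2 to compound 3 (0.11 log units; within the scatter). The estimate for compound 3 is 8000 nM, with an expected range of 3500 nM to 18000 nM.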

Compound 3, half-maximal cytotoxic concentration: 9920 nM
Beside the measured number, compound 3's estimate is 1.2-fold (0.09 log units) below it, within the range that was stated.
By their numbers in this assay, from the lowest: compounds 1, 3 and 2 (each within the scatter of the next).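

In this assay, the group with 2 chlorine on a nitrogen on an aromatic ring gives a 1.0-fold lower number from compound 2 to compound 3 (0.01 log units; within the scatter) when it replaces the 4-(2-cyanoethenyl)-2,6-dimethylphenyl group, and a 1.6-fold higher number from compound 1 to compound 3 (0.19 log units; within the scatter) when it replaces the group with 2 fluorine. Where a single step stood before, three groups can now be compared at this place, and all the steps among compounds 1, 2 and 3 lie within the scatter, so exchanging 2 fluorine, 2 methyl or 2 chlorine on this group does not separate these compounds in this assay. No supporting data accompany these numbers to account for this result.

On these data alone, all three groups keep the cyanoethenyl chain and the same six-membered aromatic ring of carbon only, so it remains open whether a group carrying an amine, two methoxy groups or two bromine atoms in their place would give a step beyond the scatter. Also open, as far as these compounds go, is whether a carboxylic acid or a longer chain in place of the cyanoethenyl chain would change the number at this place.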